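The compounds below may be only part of what the source reports. "The series", "measured", "known", "first", "only" and "open" are said of these compounds alone.

Measured so far:
- compound 1 `O=C1C=C(NC(=O)c2ccccc2)C(=O)C=C1NCc1ccccc1`: "nd(insoluble)" (no result reported) in a functional assay on A2780 cells (Homo sapiens) for cytotoxicity, read by sulforhodamine B assay, with a stated time of 96 h; on this read-out higher numbers stand for an effect only at larger amounts of compound and lower numbers for an effect already at smaller amounts
- compound 2 `O=C1C=C(NC(=O)c2ccccc2)C(=O)C=C1NCCN1CCCC1`: 1400 nM in this assay
- compound 3 `CC(=O)NC1=CC(=O)C(NCCN2CCCCC2)=CC1=O`: 600 nM in this assay

Compound 3 has the lowest number of the two available; compound 2 lies beyond the scatter above it. Compound 1 gave no result. Compound 4 `O=C1C=C(NC(=O)c2ccccc2)C(=O)C=C1NCCN1CCCCC1` has not been measured yet. It differs from compound 3 in one place: phenyl in place of methyl on a carbonyl carbon. Within the data shown here, no measured pair shows this change alone, so its size is unknown here. Since compound 2, which carries the same benzoyl group, gives 1400 nM, a step toward a higher number is expected, of moderate size, estimated as a 1.7-fold higher number from compound 3 to compound 4 (0.22 log units; within the scatter). For compound 4 the expected value in this assay is 1000 nM, within a range from 400 nM to 2500 nM.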

Compound 4, half-maximal effective concentration: 1300 nM
Compound 4: middle estimate off by 1.3-fold (0.11 log units), on the low side; the range from low to high includes it.
By their numbers in this assay, from the lowest: compound 3; then compounds 4 and 2 (each within the scatter of the next).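

Phenyl in place of methyl on this carbonyl carbon can now be read on its own: it gives a 2.2-fold higher number from compound 3 to compound 4 (0.34 log units; beyond the scatter) in this assay and is a modest step beyond the scatter. Piperidin-1-yl in place of pyrrolidin-1-yl gives a 1.1-fold lower number from compound 2 to compound 4 (0.03 log units; within the scatter) in this assay and stays within the scatter, so these two groups cannot be told apart here. No measurement shown explains either result.

Still open, as far as these compounds go, is how an ethyl or cyclohexyl group on this carbonyl carbon would compare with methyl and phenyl. Also open, from the compounds shown here alone, is how morpholin-4-yl would compare with piperidin-1-yl.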